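Methyl to methoxy on the outer aryl ring

The compounds below may be only part of what the source reports. "The series", "measured", "known", "first", "only" and "open" are said of these compounds alone.

Measured so far in a functional assay on MCF7 cells (Homo sapiens) for cytotoxicity, read by MTT assay, with a stated time of 72 h; a lower number here means a stronger inhibitor, a higher number a weaker inhibitor:
compound 1 `Cc1ccc(-c2ccnc(C(=O)Nc3ccc(Oc4ccnc5[nH]ccc45)cc3)c2)cc1`: > 10000 nM
compound 2 `COc1ccc(-c2ccnc(C(=O)Nc3ccc(Oc4ccnc5[nH]ccc45)cc3)c2)cc1`: 8210 nM
compound 3 `Cc1ccc(-c2ccc(C(=O)Nc3ccc(Oc4ccnc5[nH]ccc45)c(F)c3)nc2)cc1`: 8020 nM

The value of compound 1 is a limit of the assay and not a number; it sits at the limit of > 10000 nM in this assay, at which 1 of the 3 values shown sits. Compound 2 differs from compound 1 only by methoxy in place of methyl on an aromatic carbon. The step of an at least 1.2-fold lower number from compound 1 to compound 2 (0.08 log units; that floor lies within the scatter) runs from a limit to a number, so its size is known only as a floor. Compound 3 carries a different core; the difference between the core of compound 3 and the core of compound 1 is not broken down here. Compound 2 and compound 3 lie within the scatter of each other in this assay, and no order is read between them.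

Compound 4 `COc1ccc(-c2ccc(C(=O)Nc3ccc(Oc4ccnc5[nH]ccc45)c(F)c3)nc2)cc1` is not yet measured. Among the compounds with values here, it differs from compound 3 by methoxy in place of methyl on an aromatic carbon, the same change as the one from compound 1 to compound 2. In this assay the step is expected to be small, a 1.1-fold lower number from compound 3 to compound 4 (0.06 log units; within the scatter), resting on an at least 1.2-fold lower number from compound 1 to compound 2 (0.08 log units; that floor lies within the scatter) and on compound 3 standing at 8020 nM. The floor of an at least 1.2-fold lower number from compound 1 to compound 2 (0.08 log units; that floor lies within the scatter) lies within the scatter, so no clear movement is expected. Compound 4 is thus estimated at 7000 nM. For compound 4 the expected range runs from 3000 nM to 20000 nM, with some chance that only a limit is returned.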

Compound 4, half-maximal inhibitory concentration: 10100 nM
Beside the measured number, compound 4's estimate is 1.4-fold (0.16 log units) below it; the range from low to high includes it.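

In this assay, replacing 4-methylphenyl with 4-methoxyphenyl on the core of compound 3 gives a 1.3-fold higher number from compound 3 to compound 4 (0.10 log units; within the scatter), so no clear movement is read from this change on that core. Set beside the step on the core of compound 1, this result does not establish that the change acts alike on both cores, and no difference between them can be claimed either: the same change on two cores in this assay, an at least 1.2-fold lower number (0.08 log units; that floor lies within the scatter) from compound 1 to compound 2 and a 1.3-fold higher number (0.10 log units; within the scatter) from compound 3 to compound 4; the limit leaves it open whether they differ

The value of compound 1, > 10000 nM, is a limit of the assay and not a number, so the true size of the earlier step stays unknown and a larger step on that core is not excluded: the limit of > 10000 nM in this assay, at which 1 of the 4 values shown sits.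

The compounds shown leave open whether a different group in place of the methyl or methoxy on the outer aryl ring, such as an amine, a carboxylic acid or a longer chain, would shift the number clearly in this assay. Also open, going by these compounds, is how methoxy in place of methyl would read on a core whose value stands well away from the limit of the assay.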